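Triazole-linked dihydropyrimidinones: growth inhibition in NCI/ADR-RES cells

The compounds below may be only part of what the source reports. "The series", "measured", "known", "first", "only" and "open" are said of these compounds alone.

Measured so far:
compound 1 `C=C(C)[C@@H]1CC=C(Cn2cc(COc3ccc(C4NC(=O)NC(C)=C4C(=O)OCC)cc3OC)nn2)CC1`: > 100000 nM
compound 2 `C=C(C)[C@@H]1CC=C(Cn2cc(COc3ccc(C4NC(=O)NC(C)=C4C(C)=O)cc3)nn2)CC1`: > 100000 nM

In a functional assay on NCI/ADR-RES cells (Homo sapiens) for inhibition, read by sulforhodamine B assay, with a stated time of 48 h (on this read-out higher numbers stand for weaker inhibition of growth and lower numbers for stronger inhibition of growth), compound 1 reaches only the limit, > 100000 nM. In this assay compound 2 likewise gives only the limit, > 100000 nM. Compound 2 thus stands at the same limit as the other measured compound, and the limit of > 100000 nM in this assay, at which 2 of the 2 values shown sit, describes both values.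

Compound 3 `C=C(C)[C@@H]1CC=C(Cn2cc(COc3ccc(C4NC(=O)NC(C)=C4C(C)=O)cc3OC)nn2)CC1` carries methoxy in place of hydrogen on an aromatic carbon, with the acetyl group retained from compound 2. Within the data shown here, no measured step is available. The move from compound 2 to compound 3 is expected to give no change beyond the scatter, a number no higher from compound 2 to compound 3 (the limit leaves the size open), and compound 3 is estimated at 100000 nM (range 30000 nM to 300000 nM), most likely again reported as a limit.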

Compound 3, concentration for total growth inhibition: 80200 nM
Beside the measured number, compound 3's estimate is 1.2-fold (0.10 log units) above it, within the range that was stated.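

In this assay, compound 3 is the only compound shown that gives a number rather than a limit, and it combines the methoxy group with the acetyl group. The step for methoxy in place of hydrogen is an at least 1.2-fold lower number from compound 2 to compound 3 (0.09 log units; that floor lies within the scatter), and the step for methyl in place of ethoxy on the carbonyl carbon is an at least 1.2-fold lower number from compound 1 to compound 3 (0.09 log units; that floor lies within the scatter). Both are only floors, so neither change alone is shown to lower the number: the limit of > 100000 nM in this assay, at which 2 of the 3 values shown sit.

Still open, on these data alone, is how a hydroxyl or an amine would read in place of the methoxy group, and how a carboxylic acid or a longer chain would read in place of the acetyl group.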